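Swapping 4-(trifluoromethyl)phenyl for pyridin-4-yl in compound 4

The source may report more compounds than this note shows. Statements on the series, on what has been measured and on what is new or still open speak of the compounds shown alone.

- compound 1 `CCN(CC)c1ccc(-c2cc(Cl)cn3c([N+](=O)[O-])c(CS(=O)(=O)c4ccccc4)nc23)cc1` gives > 15600 nM as a limit
- compound 2 `O=[N+]([O-])c1c(CS(=O)(=O)c2ccccc2)nc2c(-c3ccccc3CO)cc(Cl)cn12` gives 88000 nM as a number
- compound 3 `O=[N+]([O-])c1c(CS(=O)(=O)c2ccccc2)nc2c(-c3ccc(C(F)(F)F)cc3)cc(Cl)cn12` gives > 3900 nM as a limit

All three values come from an ADME assay on HepG2 cells (Homo sapiens) for cytotoxicity, read by MTT assay, with a stated time of 72 h (a lower number here means that less compound is tolerated, a higher number that more compound is tolerated), and the compounds share one core. As far as these compounds go, compound 3 stands on a limit only, not a number, so its place against the other two stays open.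

Compound 4 `O=[N+]([O-])c1c(CS(=O)(=O)c2ccccc2)nc2c(-c3ccncc3)cc(Cl)cn12` is still to be measured. The change from compound 3 is pyridin-4-yl in place of 4-(trifluoromethyl)phenyl on an aromatic carbon on the same aromatic carbon, with pyridin-4-yl in place of 4-(trifluoromethyl)phenyl.

Steps that alter this same group gave a step that the limit leaves unreadable from compound 2 to compound 3 and a step that the two limits leave unreadable from compound 1 to compound 3 and also a step that the limit leaves unreadable from compound 1 to compound 2 so none of them offers a size to carry over. For the measured compounds named here, the one true number is compound 2 at 88000 nM in this assay and it points loosely towards more compound being tolerated. The expected outcome is a step that the limit leaves unreadable from compound 3 to compound 4 with wide uncertainty. For compound 4 the estimated value is 30000 nM with an expected range from 6000 nM to 100000 nM in this measurement.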

Compound 4, half-maximal cytotoxic concentration: > 50000 nM
Compound 4: only a limit was reported (the forecaster's own chance of this, stated with the estimate: 50%); middle value at least 1.6-fold (0.22 log units) away from the limit.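

Compound 4 gives > 50000 nM, which is a limit and not a number. For the compounds shown here, no step from compound 1, compound 2 or compound 3 to compound 4 can be read. The compounds shown leave open whether swapping these groups on the shared core changes how much compound the cells tolerate.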